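Aryl swaps on the triazole nitrogen: cytotoxicity notes

The source may hold more compounds than are shown below. What is called first, only, known or untested is meant among the compounds shown, and "the series" means these compounds.

Measured so far:
compound 1 `Cc1ccc(-n2nc(-c3ccc(C(F)(F)F)cc3O)nc2-c2ccccc2O)cc1` — 71.5%
compound 2 `Oc1cc(C(F)(F)F)ccc1-c1nc(-c2ccccc2O)n(-c2ccc(C(F)(F)F)cc2)n1` — 70.7%
compound 3 `N#Cc1ccc(-n2nc(-c3ccc(C(F)(F)F)cc3O)nc2-c2ccccc2O)cc1` — 66.6%

The read-out is a functional assay on PC-12 cells (Rattus norvegicus) for cytotoxicity, read by MTT assay, with stated times of 2 h and 24 h, tested at 1 uM; a lower number here means a weaker effect, a higher number a stronger effect of the compound at the concentration tested. Compound 3 sits at 66.6%; the gaps to its neighbours, a number 4.1 percentage points lower from compound 2 to compound 3 (within the scatter) and a number 4.9 percentage points lower from compound 1 to compound 3 (within the scatter), both lie within the scatter, so compound 3 is not separated from compound 1 or compound 2 on these numbers.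

Compound 4 `Oc1cc(C(F)(F)F)ccc1-c1nc(-c2ccccc2O)n(-c2cccc(F)c2)n1` is not yet measured. It differs from compound 3 by 3-fluorophenyl in place of 4-cyanophenyl on an aromatic nitrogen.

All three measured steps bear on this change, since each exchanges one group on the same aryl ring attached to the aromatic nitrogen of the shared core: a number 0.8 percentage points lower from compound 1 to compound 2 (within the scatter), a number 4.9 percentage points lower from compound 1 to compound 3 (within the scatter) and a number 4.1 percentage points lower from compound 2 to compound 3 (within the scatter). None of them moved the number beyond the scatter, whether methyl, trifluoromethyl or cyano sat on that ring. The exchange of 4-cyanophenyl for 3-fluorophenyl is therefore expected to give no step beyond the scatter in this assay, in either direction.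

Compound 4 is estimated at 68%, with a range of 59% to 77%, which means an expected step of a number 1.4 percentage points higher from compound 3 to compound 4 (within the scatter) from compound 3.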

Compound 4, a percentage reported as activity, at one concentration (the size of the read-out at that concentration, not a potency): 67.2%
For compound 4 the middle estimate is 0.8 percentage points above the measured one; low and high end bracket the measured number.
By their numbers in this assay, from the lowest: compounds 3, 4, 2 and 1 (each within the scatter of the next).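

In this assay, 3-fluorophenyl on the aromatic nitrogen is not separated from any of the three groups it replaces: a number 0.6 percentage points higher from compound 3 to compound 4 (within the scatter), a number 3.5 percentage points lower from compound 2 to compound 4 (within the scatter) and a number 4.3 percentage points lower from compound 1 to compound 4 (within the scatter). The earlier steps shown here compared only 4-methylphenyl, 4-(trifluoromethyl)phenyl and 4-cyanophenyl, so they exchanged the group while its number on the phenyl ring stayed at 4. Among these compounds, with 3-fluorophenyl, the group and its number on the ring differ together, and across compounds 1 to 4 neither exchange gives a step beyond the scatter, with no compound among the four going against this.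

Still open, going by these compounds, is whether a phenyl ring carrying an amine or a carboxylic acid, or a longer alkyl chain in place of the aryl group on this nitrogen, would give a step beyond the scatter, and whether fluorine at the 4 number of the ring would read differently from 3-fluorophenyl. Nothing at hand accounts for the closeness of these four numbers.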